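Working notes: bromo in place of methoxy, compound 4

The source may hold more compounds than are shown below. What is called first, only, known or untested is meant among the compounds shown, and "the series" means these compounds.

Values in a functional assay (Homo sapiens) for inhibition (a lower number here means a stronger inhibitor, a higher number a weaker inhibitor), for the measured compounds
Compound 1 `COc1cc(/C=C/C(=O)c2ccccc2[N+](=O)[O-])cc(OC)c1` gives 3700 nM
Compound 2 `COc1ccc(/C=C/C(=O)c2cccc([N+](=O)[O-])c2)c(OC)c1` gives 18000 nM
Compound 3 `COc1cccc(C(=O)/C=C/c2ccc(OC)cc2OC)c1` gives 42000 nM

Compound 3 at 42000 nM carries the highest number of the three. Compound 2 lies nearest to it and compound 1 lies furthest. For the measured compounds named here, compound 4 `COc1ccc(/C=C/C(=O)c2cccc(Br)c2)c(OC)c1` has no measurement yet. Compound 4 departs from compound 3 by bromo in place of methoxy on an aromatic carbon and so has bromo in place of methoxy on an aromatic carbon.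

Going by the values given here, the one measured step that bears on this is a 2.3-fold higher number from compound 2 to compound 3 (0.37 log units; beyond the scatter) and it is modest, with methoxy in place of nitro on an aromatic carbon. That step brings in the group that leaves here. Among the compounds with values here, no bromo compound has been measured, so whether bromo tracks nitro remains open. Within the data shown here, compound 1 differs from compound 2 in more than one place and offers no single-change step.

Among the measured compounds shown here, with compound 2 at 18000 nM as the only guide, a move back toward a lower number is expected. Expected in this assay is a 2.1-fold lower number from compound 3 to compound 4 (0.32 log units; beyond the scatter) as a modest step of about the measured size. The estimate for compound 4 is 20000 nM with 8000 nM to 48000 nM as its expected range.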

Compound 4, half-maximal inhibitory concentration: 37000 nM
For compound 4 the middle estimate is 1.9-fold (0.27 log units) below the measured one, and the stated range covers the measured number.
By their numbers in this assay, from the lowest: compound 1; then compound 2; then compounds 4 and 3 (each within the scatter of the next).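

In this assay bromo and methoxy cannot be told apart on this aromatic carbon, meta to a large group, with a 1.1-fold lower number from compound 3 to compound 4 (0.06 log units; within the scatter) and the hydrogen-bond acceptor counted on methoxy gone from bromo without a step beyond the scatter. Nitro now stands apart from two groups at this carbon rather than one, with a 2.1-fold higher number from compound 2 to compound 4 (0.31 log units; beyond the scatter) alongside the earlier 2.3-fold higher number from compound 2 to compound 3 (0.37 log units; beyond the scatter), and these two modest steps place compound 2 on the lower side of both compound 3 and compound 4. Nothing measured on these groups accounts for the position of nitro, so the separation remains an observation on these three compounds alone.

On these data alone, whether an amine, a carboxylic acid or a hydroxyl on the same carbon would sit with nitro or with the bromo and methoxy pair remains open, and three groups at one position give no trend to extend to them. As far as these compounds go, compound 1 at 3700 nM differs from the others in more than one place, so its steps to them cannot be read, and what the nitro group contributes at another ring carbon also stays open.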